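Swapping the acyl aryl group on two quinazoline thiosemicarbazide cores

This account rests on a few compounds, and the source may have more. Where it says the series, first, only, none or still open, it means among the compounds named here.

The study measured three compounds in a functional assay on GLC82 cells (Homo sapiens) for cytotoxicity, read by MTT assay, with a stated time of 72 h (on this read-out lower numbers stand for stronger inhibition and higher numbers for weaker inhibition), and leaves a fourth to be estimated. Compound 1, `COc1cc2ncnc(NNC(=S)NC(=O)c3ccccc3Cl)c2cc1OC`, gives 10000 nM in this assay. Compound 2, `COc1cc2ncnc(NNC(=S)NC(=O)c3ccc(C)cc3)c2cc1OC`, gives 29900 nM in this assay. Compound 3, `Cc1ccc(C(=O)NC(=S)NNc2ncnc3ccccc23)cc1`, gives 11200 nM in this assay, which places compound 3 within the scatter of compound 1 and beyond it relative to compound 2.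

Compound 2 and compound 1 share one core and differ by 2-chlorophenyl in place of 4-methylphenyl on a carbonyl carbon; this change gives a 3.0-fold lower number from compound 2 to compound 1 (0.48 log units; beyond the scatter). Compound 3 carries the other core, and the difference between the two cores is not broken down here.

Compound 4, `O=C(NC(=S)NNc1ncnc2ccccc12)c1ccccc1Cl`, is the unmeasured member. It differs from compound 3 by 2-chlorophenyl in place of 4-methylphenyl on a carbonyl carbon, at a place described in the same words as for the pair of compound 2 and compound 1, so the same change is made a second time, now on the core of compound 3. Its size is known once only, and the two cores are not matched by any counted difference, so the carry-over is uncertain.

For the measured compounds named here, compound 4 is expected to show a 2.5-fold lower number from compound 3 to compound 4 (0.40 log units; beyond the scatter) in this assay, a step of the same direction as the measured one, slightly damped for the single precedent. The estimate for compound 4 in this assay is 4500 nM, with a plausible range from 1800 nM to 11000 nM.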

Compound 4, half-maximal inhibitory concentration: 10800 nM
Estimate against measurement, compound 4: 2.4-fold (0.38 log units) below; low and high end bracket the measured number.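

On the core of compound 3, 2-chlorophenyl in place of 4-methylphenyl on a carbonyl carbon gives a 1.0-fold lower number from compound 3 to compound 4 (0.02 log units; within the scatter) in this assay, so the step seen on the core of compound 2 does not reappear at a size that can be told from the scatter. Set side by side, the two steps differ, and the size of this change does not carry over from one core to the other in this series: the same change on two cores in this assay, a 3.0-fold lower number (0.48 log units; beyond the scatter) from compound 2 to compound 1 and a 1.0-fold lower number (0.02 log units; within the scatter) from compound 3 to compound 4, 2.9-fold (0.46 log units) apart, beyond the scatter of two such steps. This rests on just two matched pairs in a single cell assay, so it shows that the size of the step depends on the core here, but not what in the two cores is responsible, nor how the change would behave on any further core.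

The compounds shown place only 4-methylphenyl and 2-chlorophenyl on the carbonyl carbon, so it remains open whether other groups in that place, such as an amine or a carboxylic acid on the phenyl ring, or a longer alkyl chain in place of the ring, would give steps that differ between the two cores. It also remains open whether the difference between the two steps would persist in cell lines other than the one shown.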